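Changing the sulfur substituent in a thioenone series

The source may report more compounds than this note shows. Statements on the series, on what has been measured and on what is new or still open speak of the compounds shown alone.

Compound 1 `Cc1ccc(CS/C(=C/c2c[nH]c3ccc(Br)cc23)C(=O)c2ccc(Cl)cc2)cc1`: 1000 nM
Compound 2 `COc1ccccc1/C=C(/SCc1ccc(C)cc1)C(=O)c1ccc(Cl)cc1`: 10000 nM
Compound 3 `Cc1ccc(CS/C(=C/c2ccccc2OCc2ccccc2)C(=O)c2ccc(Cl)cc2)cc1`: 1000 nM

Of the compounds shown here, three have been measured in a functional assay on DU-145 cells (Homo sapiens) for inhibition, read by trypan blue exclusion, with a stated time of 96 h; a lower number here means a stronger inhibitor of growth, a higher number a weaker inhibitor of growth. Compound 2 stands highest of the three: the step of a 10-fold higher number from compound 1 to compound 2 (1.00 log units; beyond the scatter) and the step of a 10-fold lower number from compound 2 to compound 3 (1.00 log units; beyond the scatter) both lie beyond the scatter, so compound 2 is the weakest growth inhibitor of this set.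

Compound 4 `COc1ccccc1/C=C(/Sc1ccc(Br)cc1)C(=O)c1ccc(Cl)cc1` differs from compound 2 in one place: 4-bromophenyl in place of 4-methylbenzyl on a sulfur. Neither measured step concerns this sulfur. The step from compound 1 to compound 2 changes the group on the double-bonded chain carbon, and the step from compound 2 to compound 3 adds a phenyl on a saturated chain carbon bound to an oxygen on an aromatic ring; both leave the (4-methylbenzyl)sulfanyl untouched. The data therefore give no direction for the change to (4-bromophenyl)sulfanyl.

For the measured compounds named here, with no guiding step, compound 4 is expected to stay near compound 2, with a wide range, giving a 1.3-fold lower number from compound 2 to compound 4 (0.10 log units; within the scatter) as the estimated step. The estimate for compound 4 is 8000 nM, between 2000 nM and 30000 nM.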

Compound 4, concentration for 50% growth inhibition: 10000 nM
For compound 4 the middle estimate is 1.3-fold (0.10 log units) below the measured one, and the stated range covers the measured number.
By their numbers in this assay, from the lowest: compounds 1 and 3 (each within the scatter of the next); then compounds 2 and 4 (each within the scatter of the next).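

In this assay, the sulfur position gets its first reading: 4-bromophenyl in place of 4-methylbenzyl gives no change at the digits printed from compound 2 to compound 4 (within the scatter) and so stays within the scatter. The earlier steps shown here all left this sulfur substituent untouched, so this pair alone shows that, on the core of compound 2, the two groups read alike. It is one pair, however, and it shows no gain in growth inhibition from this change. No supporting measurement bears on this result.

As far as these compounds go, whether the same change reads alike on the cores of compound 1 and compound 3, which carry the lower numbers, stays open. Also open, from the compounds shown here alone, is how a longer chain, an amine or a carboxylic acid in place of these groups on the sulfur would read.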